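Ethylamino to dimethylamino on a second core

This account rests on a few compounds, and the source may have more. Where it says the series, first, only, none or still open, it means among the compounds named here.

Measured in a functional assay on A549 cells (Homo sapiens) for antiproliferative activity, read by MTT assay, with a stated time of 48 h; a lower number here means a stronger inhibitor, a higher number a weaker inhibitor:

compound 1 `CCNCC(=O)Nc1cc(OC)ccc1C(=O)c1ccc2c(c1)C=CC(C)(C)O2` gives 1300 nM
compound 2 `COc1ccc(C(=O)c2ccc3c(c2)C=CC(C)(C)O3)c(NC(=O)CN(C)C)c1` gives 1160 nM
compound 3 `C=C(c1ccc(OC)cc1NC(=O)CNCC)c1ccc(OC)c2c1C=CC(C)(C)O2` gives 1870 nM

The three values lie within the usual scatter of one another, so no order among them is claimed. Compounds 1 and 2 differ only by dimethylamino in place of ethylamino on a saturated chain carbon bound to a carbonyl carbon, and that change gave a 1.1-fold lower number from compound 1 to compound 2 (0.05 log units; within the scatter), a step that does not leave the scatter.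

Compound 4 `C=C(c1ccc(OC)cc1NC(=O)CN(C)C)c1ccc(OC)c2c1C=CC(C)(C)O2` is compound 3 with the same change, (dimethylamino in place of ethylamino on a saturated chain carbon bound to a carbonyl carbon). The place described for both changes is the same word for word, so this is the same change made on a second core; how the core of compound 3 differs from the core of compound 1 is not broken down here, only that it differs in more than one place.

Within the data shown here, because the one measured instance of this change, a 1.1-fold lower number from compound 1 to compound 2 (0.05 log units; within the scatter), stayed within the scatter, the step expected from compound 3 to compound 4 is a 1.1-fold lower number from compound 3 to compound 4 (0.04 log units; within the scatter) in this assay. Compound 4 is estimated at 1700 nM in this assay, with an expected range from 850 nM to 3400 nM.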

Compound 4, half-maximal inhibitory concentration: 550 nM
Compound 4: middle estimate off by 3.1-fold (0.49 log units), on the high side; the whole stated range lies above it.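

In this assay, dimethylamino in place of ethylamino on the core of compound 3 gave a 3.4-fold lower number from compound 3 to compound 4 (0.53 log units; beyond the scatter), so the change did not carry over at one size from the core of compound 1 to the core of compound 3: the same change on two cores in this assay, a 1.1-fold lower number (0.05 log units; within the scatter) from compound 1 to compound 2 and a 3.4-fold lower number (0.53 log units; beyond the scatter) from compound 3 to compound 4, 3.0-fold (0.48 log units) apart, beyond the scatter of two such steps

The size of this step therefore cannot be taken as fixed when moving between these two cores, although the direction of the number is not in conflict on either core, and the step on the core of compound 1 stays within the scatter. This rests on one pair of compounds per core, and those cores differ in more than one place, so it shows neither which core difference goes with the larger step nor why the steps differ.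

Still open, as far as these compounds go, is whether a core differing from that of compound 1 in one place only would give the larger step. Also open, from the compounds shown here alone, is whether diethylamino, pyrrolidin-1-yl, morpholin-4-yl or a longer chain carrying the amine would follow the same course on both cores.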